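The compounds below may be only part of what the source reports. "The series", "measured", "known", "first", "only" and "open" are said of these compounds alone.

Compound 1 `O=C(NCc1ccccc1)c1c(O)c2cccnc2n(-c2ccccc2)c1=O` serves as the reference point of the series. In a functional assay on the whole organism for inhibition, with Rattus norvegicus as the target, read by paw edema, at a dose of 100 mg/kg by the oral route (on this read-out higher numbers stand for more inhibition at the one dose given (going by the name of the read-out) and lower numbers for less inhibition), compound 1 gives 1.6%. Among the three numbers shown it sits in the middle: compound 3 `COc1cccc(NC(=O)c2c(O)c3cccnc3n(-c3ccccc3)c2=O)c1` gives 5.7%, which lies within the scatter of compound 1, while compound 2 `O=C(NN1CCOCC1)c1c(O)c2cccnc2n(-c2ccccc2)c1=O` gives -8.5%, which lies beyond it. The two steps out of compound 1 read a number 10.1 percentage points lower from compound 1 to compound 2 (beyond the scatter) and a number 4.1 percentage points higher from compound 1 to compound 3 (within the scatter); between the other two the step reads a number 14.2 percentage points higher from compound 2 to compound 3 (beyond the scatter).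

Compound 4 `O=C(Nc1nccs1)c1c(O)c2cccnc2n(-c2ccccc2)c1=O` has not yet been measured. Relative to compound 1 the change is 1,3-thiazol-2-yl in place of benzyl on an amide-type nitrogen. For the measured compounds named here, the steps that bear on it are the two from compound 1: morpholin-4-yl on the amide-type nitrogen gave a number 10.1 percentage points lower from compound 1 to compound 2 (beyond the scatter), whereas 3-methoxyphenyl on that nitrogen gave a number 4.1 percentage points higher from compound 1 to compound 3 (within the scatter). Compound 4 carries an aromatic ring directly on the amide-type nitrogen, as compound 3 does, so the step of a number 1.4 percentage points higher from compound 1 to compound 4 (within the scatter) is expected to remain within the scatter, with no clear direction; the fall to compound 2 is the only measured argument for a lower number. Compound 4 is therefore estimated at 3%, with a range from -10% to 16%.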

Compound 4, a percentage reported as inhibition, in the whole organism at one dose (the size of the read-out at that dose, not a potency): 4.6%
Compound 4: the middle estimate sits 1.6 percentage points below what was measured, and the stated range covers the measured number.
By their numbers in this assay, from the lowest: compound 2; then compounds 1, 4 and 3 (each within the scatter of the next).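

The step in this assay for 1,3-thiazol-2-yl in place of benzyl on the amide-type nitrogen (a number 3 percentage points higher from compound 1 to compound 4 (within the scatter)) shows that a five-membered aromatic ring with 2 hetero atoms and 2 hydrogen-bond acceptors gives no readable change from benzyl, which has neither hetero atoms nor acceptors. The comparison with the carbon-only ring of 3-methoxyphenyl (a number 1.1 percentage points lower from compound 3 to compound 4 (within the scatter)) also gives no readable difference, while the step up from morpholin-4-yl (a number 13.1 percentage points higher from compound 2 to compound 4 (beyond the scatter)) matches the one already seen for 3-methoxyphenyl (a number 14.2 percentage points higher from compound 2 to compound 3 (beyond the scatter)), so compound 2 now stands apart from compounds 1, 3 and 4 at this position. No measurement at hand accounts for any of these steps.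

Still open, going by these compounds, is whether any group on this nitrogen can lift the number beyond the scatter of compound 1, for example a benzyl carrying a carboxylic acid, a dimethylamino group or a longer chain such as 2-phenylethyl. Also open, on these data alone, is whether the lower number of compound 2 belongs to morpholin-4-yl in particular or extends to other saturated rings, such as cyclohexyl or piperidin-1-yl.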